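The compounds below may be only part of what the source reports. "The series", "measured", "known", "first", "only" and "open" are said of these compounds alone.

Of the compounds shown here, three have been tested in an ADME assay on NCI-H630 cells (Homo sapiens) for cytotoxicity, read by MTT assay, with a stated time of 72 h (on this read-out higher numbers stand for lower toxicity in this test and lower numbers for higher toxicity in this test), and none of them yielded a number. Compound 1 `O=C(O)c1cccc(OCc2ccccc2)c1O` reached only the limit of the test, > 40000 nM. Compound 2 `O=C(O)c1cccc(OCc2ccc3ccccc3c2)c1O` likewise gave only the limit, > 40000 nM. Compound 3 `O=C(O)c1cc(OCc2ccccc2)ccc1O` also stopped at the limit, > 40000 nM. Since all three results sit at the limit of > 40000 nM in this assay, at which 3 of the 3 values shown sit, compound 3 cannot be placed above or below either of the others; it stands exactly where every measured compound stands, at the edge of what this test can report.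

Compound 4 `O=C(O)c1cc(OCc2ccc(F)cc2)ccc1O` is still to be measured. It differs from compound 3 by fluoro in place of hydrogen on an aromatic carbon. Among the compounds with values here, no step between two measured compounds is available to show what such a change does in this assay, so the size of the change cannot be read from the data. Because the three measured compounds all sit at the limit of > 40000 nM in this assay, at which 3 of the 3 values shown sit, the expectation is that compound 4 will again be reported only as a limit, and the expected step from compound 3 to compound 4 is a step that the limit leaves unreadable from compound 3 to compound 4. The estimate for compound 4 in this assay is therefore 60000 nM, within a range from 30000 nM to 200000 nM.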

Compound 4, half-maximal cytotoxic concentration: > 40000 nM
Compound 4: no number, only a limit (the forecaster's own chance of this, stated with the estimate: 80%); the middle value is on the limit's open side.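

Compound 3 and compound 4 are both reported only as limits, so no step from one to the other can be read: the limit of > 40000 nM in this assay, at which 4 of the 4 values shown sit.

The compounds shown leave open what fluoro in place of hydrogen on an aromatic carbon does in this assay, and what concentration of any of them would harm these cells.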